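Compound 3 to compound 4: a new group on the carbonyl

The source may hold more compounds than are shown below. What is called first, only, known or untested is meant among the compounds shown, and "the series" means these compounds.

Values in a functional assay on HepG2 cells (Homo sapiens) for antiproliferative activity, read by MTT assay, with a stated time of 48 h (on this read-out lower numbers stand for stronger inhibition and higher numbers for weaker inhibition), follow.
- compound 1 `CCn1c(C(=O)NCCN(C)C)ccc1C(CC)(CC)c1ccc(OCCC(O)(CC)CC)c(C)c1` gives 240 nM
- compound 2 `C#CC(C)OC(=O)c1ccc(C(CC)(CC)c2ccc(OCCC(O)(CC)CC)c(C)c2)n1CC` gives > 50000 nM as a limit
- compound 3 `C#CCCOC(=O)c1ccc(C(CC)(CC)c2ccc(OCCC(O)(CC)CC)c(C)c2)n1CC` gives > 50000 nM as a limit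

Compound 3 stands at the limit of > 50000 nM in this assay, at which 2 of the 3 values shown sit, with no number of its own. The move to compound 4 `CCC(C)C(NC(=O)c1ccc(C(CC)(CC)c2ccc(OCCC(O)(CC)CC)c(C)c2)n1CC)C(=O)OC` changes the group on a carbonyl carbon (a group of 10 heavy atoms (7 carbon, 1 nitrogen, 2 oxygen; no ring) in place of a group of 5 heavy atoms (4 carbon, 1 oxygen; no ring), on a carbonyl carbon). Two measured steps at this same carbonyl carbon bear on it, an at least 200-fold higher number from compound 1 to compound 2 (2.31 log units; beyond the scatter) and an at least 200-fold higher number from compound 1 to compound 3 (2.31 log units; beyond the scatter), both large and beyond the scatter. The group in compound 4 matches none of those three groups, so a partial recovery in this assay is expected, not a full one. The expected change, towards a lower number, is an at least 4.1-fold lower number from compound 3 to compound 4 (0.61 log units; beyond the scatter), though another limit remains possible. For compound 4 the estimate is 12000 nM, with an expected range of 1500 nM to 50000 nM.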

Compound 4, half-maximal inhibitory concentration: > 50000 nM
Compound 4 gave a limit, no number (the forecaster's own chance of this, stated with the estimate: 35%); middle value at least 4.1-fold (0.61 log units) from the limit.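

Keeping an amide on the carbonyl is not enough in this assay: with the amide-type nitrogen kept, putting the ester-bearing chain of compound 4 in place of the 2-(dimethylamino)ethyl group of compound 1 gives an at least 200-fold higher number from compound 1 to compound 4 (2.31 log units; beyond the scatter). Among these compounds, then, a measurable value goes with what the amide nitrogen carries, not with the amide alone, and compound 4 sits with the two esters: the limit of > 50000 nM in this assay, at which 3 of the 4 values shown sit. The steps among compound 2, compound 3 and compound 4 cannot be read.

Still open, from the compounds shown here alone, is whether a shorter amine chain on that nitrogen, or a carboxylic acid in place of the ester of compound 4, would give a measurable value.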